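Dimethylcarbamoyl in place of the charged ring on compound 2

A few compounds are considered here, and "the series" means these few. Any claim that something is new, unique, unknown or untested is made for them only; others in the source may bear on it.

Compound 2 `COc1ccc(-c2nc(/N=C(\N)[N+]3(C)CCCCC3)sc2-c2ccc(OC)cc2)cc1` stands only at a limit in a functional assay with Oryctolagus cuniculus as the target; a lower number here means a stronger inhibitor, a higher number a weaker inhibitor. Compound 2 gives > 1000 nM, a limit of the assay rather than a number. Compound 1 `COc1ccc(-c2nc(N=C(N)N)sc2-c2ccc(OC)cc2)cc1` gives 31000 nM. Compound 3 `COc1ccc(-c2nc(CNC(=O)CSC)sc2-c2ccc(OC)cc2)cc1` gives < 100 nM, likewise a limit. The data show a step that the limit leaves unreadable from compound 1 to compound 2, whereas an at least 310-fold lower number from compound 1 to compound 3 (2.49 log units; beyond the scatter) and an at least 10-fold lower number from compound 2 to compound 3 (1.00 log units; beyond the scatter) both lowered the number. Compound 4 `COc1ccc(-c2nc(C(=O)N(C)C)sc2-c2ccc(OC)cc2)cc1` carries a group of 5 heavy atoms (3 carbon, 1 nitrogen, 1 oxygen; no ring) in place of a group of 10 heavy atoms (7 carbon, 3 nitrogen; one six-membered non-aromatic ring with 1 hetero atom), on an aromatic carbon. Of the measured steps, an at least 10-fold lower number from compound 2 to compound 3 (1.00 log units; beyond the scatter) is the closest parallel, as that exchange also removes the ring and the net charge at the same aromatic carbon. A lowering beyond the scatter is therefore expected, an at least 1.2-fold lower number from compound 2 to compound 4 (0.09 log units; that floor lies within the scatter). Compound 4 is estimated at 800 nM, within 100 nM to 6000 nM.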

Compound 4, half-maximal inhibitory concentration: < 100 nM
Compound 4: no number, only a limit; the forecaster's own chance of this, stated with the estimate: 35%; at least 8.0-fold (0.90 log units) between middle value and limit.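

Compound 4 stands at a limit of the assay, not at a number. In this assay the dimethylcarbamoyl group gives an at least 10-fold lower number from compound 2 to compound 4 (1.00 log units; beyond the scatter) and an at least 310-fold lower number from compound 1 to compound 4 (2.49 log units; beyond the scatter) so the longer chain of compound 3 is not needed at this aromatic carbon to reach that limit. The step between compound 3 and compound 4 cannot be read because both sit at one limit: the limit of < 100 nM in this assay, at which 2 of the 4 values shown sit.

Going by these compounds, how far either compound lies past that limit stays open. Also open, on these data alone, is whether a carboxylic acid, a primary amide or a pyrrolidine amide at this carbon would stay there.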